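Swapping a Thioester Tail for a Chloromethyl End

A few compounds are considered here, and "the series" means these few. Any claim that something is new, unique, unknown or untested is made for them only; others in the source may bear on it.

Compound 3 `CSC(=O)CCCCc1cnc(C(=O)CCCCCCc2ccccc2)o1` carries the lowest of the three numbers measured in an assay for inhibition of Fatty-acid amide hydrolase 1 (Rattus norvegicus), using a Dixon plot (a lower number here means a stronger inhibitor, a higher number a weaker inhibitor), where compound 3 gives 1.8 nM; yet compound 2 `N#C/C=C/c1ccc(-c2cnc(C(=O)CCCCCCc3ccccc3)o2)nc1` with 2.1 nM and compound 1 `COC(=O)c1ccc(-c2cnc(C(=O)CCCCCCc3ccccc3)o2)nc1` with 3.1 nM both lie within the scatter of it, so none of the three can be called the stronger inhibitor. Within the data shown here, the only single-change step among them, a 1.5-fold lower number from compound 1 to compound 2 (0.17 log units; within the scatter), concerns a substituent on the aromatic ring, not the saturated chain. Compound 4 `O=C(CCCCCCc1ccccc1)c1ncc(CCCCCCl)o1` differs from compound 3 by chloromethyl in place of (methylsulfanyl)carbonyl on a saturated chain carbon, four bonds along the chain from an aromatic carbon. Among the measured compounds shown here, no measured step touches this chain position, so the expectation rests on the shared core and its consistently low numbers. The change is expected to amount to a 2.2-fold higher number from compound 3 to compound 4 (0.35 log units; beyond the scatter). Compound 4 is therefore estimated at 4 nM, with a range from 1.2 nM to 14 nM.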

Compound 4, inhibition constant: 5.2 nM
Compound 4: the middle estimate sits 1.3-fold (0.11 log units) below what was measured; the range from low to high includes it.
By their numbers in this assay, from the lowest: compounds 3, 2, 1 and 4 (each within the scatter of the next, the first and the last beyond it).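

Replacing (methylsulfanyl)carbonyl with chloromethyl on a saturated chain carbon, four bonds along the chain from an aromatic carbon, gives a 2.9-fold higher number from compound 3 to compound 4 (0.46 log units; beyond the scatter) in this assay, and this step lies beyond the scatter. The only earlier step changed a substituent on an aromatic carbon and stayed within the scatter, so this chain position is the first shown to shift the number, though compound 4 remains a low-nanomolar inhibitor. No measured evidence here explains the shift.

The compounds shown leave open whether an amine, a carboxylic acid or a longer chain at this position would keep the number as low. They also cannot separate the effect of losing (methylsulfanyl)carbonyl from that of gaining chloromethyl.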